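Swapping the ring on the carbonyl: furan to 1,2-oxazole

A few compounds are considered here, and "the series" means these few. Any claim that something is new, unique, unknown or untested is made for them only; others in the source may bear on it.

Of the compounds shown here, three sharing one core have been tested in an ADME assay on Huh-7 cells (Homo sapiens) for cytotoxicity; a higher number here means that more compound is tolerated, a lower number that less compound is tolerated. Compound 1 `O=C(NC(=S)N1CCc2c(OCCCCCOc3ccc(Cl)cc3)cccc21)c1ccc(Cl)cc1` carries a 4-chlorophenyl group on the carbonyl carbon and gives 21700 nM. Compound 2 `O=C(NC(=S)N1CCc2c(OCCCCCOc3ccc(Cl)cc3)cccc21)c1ccco1` carries a furan-2-yl group there and gives 4620 nM. Compound 3 `O=C(NC(=S)N1CCc2c(OCCCCCOc3ccc(Cl)cc3)cccc21)c1ccoc1` carries a furan-3-yl group and gives 20100 nM, which places it second highest of the three, close to compound 1 and well apart from compound 2.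

Compound 4 `O=C(NC(=S)N1CCc2c(OCCCCCOc3ccc(Cl)cc3)cccc21)c1ccno1` is not yet measured. It differs from compound 3 in one place: 1,2-oxazol-5-yl in place of furan-3-yl on a carbonyl carbon.

Two measured steps change the ring at this same carbonyl carbon and so bear on this one. The step of a 1.1-fold lower number from compound 1 to compound 3 (0.03 log units; within the scatter) shows that replacing 4-chlorophenyl with furan-3-yl left the number essentially unchanged, whereas the step of a 4.4-fold higher number from compound 2 to compound 3 (0.64 log units; beyond the scatter) shows that moving from furan-2-yl to furan-3-yl gave a modest rise. Changes at this position have therefore ranged from nothing to modest. For 1,2-oxazol-5-yl, a five-membered ring with two hetero atoms in place of one, a small to modest movement is expected, most plausibly downward, giving a 1.7-fold lower number from compound 3 to compound 4 (0.22 log units; within the scatter). Compound 4 is thus estimated at 12000 nM, within a range from 4000 nM to 30000 nM.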

Compound 4, half-maximal cytotoxic concentration: 37100 nM
For compound 4 the middle estimate is 3.1-fold (0.49 log units) below the measured one; measured number above the stated range.
By their numbers in this assay, from the lowest: compound 2; then compounds 3, 1 and 4 (each within the scatter of the next).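

In this assay, the 1,2-oxazol-5-yl ring brings a second hetero atom and a second hydrogen-bond acceptor to the five-membered ring, yet it cannot be told apart from furan-3-yl (a 1.8-fold higher number from compound 3 to compound 4 (0.27 log units; within the scatter)) or from 4-chlorophenyl (a 1.7-fold higher number from compound 1 to compound 4 (0.23 log units; within the scatter)). The one clear separation is from furan-2-yl (an 8.0-fold higher number from compound 2 to compound 4 (0.90 log units; beyond the scatter)), the largest step yet seen on this carbonyl carbon, so among the four rings now tested furan-2-yl alone stands apart, while the other three rings, one six-membered and two five-membered, lie within the scatter of one another. No measured information is available to explain why furan-2-yl differs from the others.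

The compounds shown leave open whether the tolerance seen with these three rings extends to a pyridine ring, to a ring carrying a carboxylic acid or an amine, or to a simple open alkyl chain in place of a ring on this carbonyl carbon. As far as these compounds go, all four compounds also share the same core, so whether furan-2-yl would stand apart in the same way on a different core remains unknown.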